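The source may report more compounds than this note shows. Statements on the series, on what has been measured and on what is new or still open speak of the compounds shown alone.

Of the compounds shown here, three have so far been measured in an ADME assay on MDCK-MDR1 cells (Canis lupus familiaris) for permeability, in the apical to basolateral direction, with a stated time of 180 min; on this read-out higher numbers stand for higher permeability and lower numbers for lower permeability. Compound 1 `CC(=O)N1CC(C(=O)Nc2ccc(C3CCCCC3)cc2)C1` gives 18.7 10^-6 cm/s in this assay, the highest of the three numbers. Compound 3 `O=C(c1ccc([C@H]2[C@@H](F)[C@@H](F)C[C@@H](F)[C@H]2F)cc1)N1CC(O)C1` gives 6.7 10^-6 cm/s, which puts compound 1 above it by a gap beyond the scatter, and compound 2 `NC(=O)CCNC(=O)c1ccc([C@H]2[C@@H](F)[C@@H](F)C[C@@H](F)[C@H]2F)cc1` gives 0.4 10^-6 cm/s, the number furthest from compound 1. Going by the values given here, the only step between two measured compounds that differ in a single place is a 17-fold higher number from compound 2 to compound 3 (1.22 log units; beyond the scatter).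

Compound 4 `CC(C(=O)Nc1ccc(C2CCCCC2)cc1)n1cncn1` has not been measured yet. It differs from compound 1 in one place: 1-(1H-1,2,4-triazol-1-yl)ethyl in place of 1-acetylazetidin-3-yl on a carbonyl carbon. Among the compounds with values here, no measured step covers this kind of exchange. Within the data shown here, the step from compound 2 to compound 3 swaps other groups on a different core, so it shows only that a swap at the carbonyl carbon can move the number a great deal, without saying which way this one would go. With the core of compound 1 kept, compound 4 is expected to land near compound 1, the expected step of a 1.2-fold lower number from compound 1 to compound 4 (0.10 log units; within the scatter) lying within the scatter. The estimate for compound 4 is 15 10^-6 cm/s, with a range from 6 10^-6 cm/s to 40 10^-6 cm/s.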

Compound 4, apparent permeability: 29.5 10^-6 cm/s
Estimate against measurement, compound 4: 2.0-fold (0.29 log units) below; measured number inside the range.
By their numbers in this assay, from the lowest: compound 2; then compound 3; then compounds 1 and 4 (each within the scatter of the next).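

The exchange of 1-acetylazetidin-3-yl for 1-(1H-1,2,4-triazol-1-yl)ethyl on a carbonyl carbon comes out as a 1.6-fold higher number from compound 1 to compound 4 (0.20 log units; within the scatter) in this assay, so on the core of compound 1 this place takes a five-membered aromatic ring with 3 hydrogen-bond acceptors instead of a four-membered non-aromatic ring with 1, and the two numbers cannot be told apart. Going by these compounds alone, the only earlier step at a carbonyl carbon, a 17-fold higher number from compound 2 to compound 3 (1.22 log units; beyond the scatter) on a different core, was large, so a swap at such a carbon need not move the number far. No measurement shown explains this outcome.

As far as these compounds go, how an amine or a carboxylic acid in this place on the core of compound 1 would read stays open. So does whether the 3-hydroxyazetidin-1-yl group of compound 3 would behave there as it does on its own core.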